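A few compounds are considered here, and "the series" means these few. Any claim that something is new, unique, unknown or untested is made for them only; others in the source may bear on it.

Three compounds have numbers in a functional assay on DU-145 cells (Homo sapiens) for inhibition, read by CCK-8 assay, with a stated time of 72 h; on this read-out lower numbers stand for stronger inhibition and higher numbers for weaker inhibition. Compound 1 `O=C(/C=C/c1cccnc1)NCCCCCc1ccc(S(=O)(=O)Nc2ccccc2)cc1` gives 581 nM, compound 2 `Cc1ccc(NS(=O)(=O)c2cccc(CCCCCCNC(=O)/C=C/c3cccnc3)c2)cc1` gives 34.4 nM, and compound 3 `Cc1ccccc1NS(=O)(=O)c1cccc(CCCCCCNC(=O)/C=C/c2cccnc2)c1` gives 2.9 nM, the lowest number of the three and so the strongest inhibition. Compound 4 `Cc1ccc(C)c(NS(=O)(=O)c2cccc(CCCCCCNC(=O)/C=C/c3cccnc3)c2)c1`, still unmeasured, has methyl in place of hydrogen on an aromatic carbon of compound 3, para to a methyl group, which turns 2-methylphenyl into 2,5-dimethylphenyl (methyl in place of hydrogen on an aromatic carbon).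

Within the data shown here, only one measured step touches this ring: a 12-fold lower number from compound 2 to compound 3 (1.07 log units; beyond the scatter), with 2-methylphenyl in place of 4-methylphenyl. That large step shows that the placing of a single methyl can shift the number well beyond the scatter. However, it moved a methyl rather than adding a second one, and no measured compound carries two methyls, so it offers only a loose guide. A modest move towards a higher number in this assay seems most likely, with a wide margin on both sides. The expected change is a 1.7-fold higher number from compound 3 to compound 4 (0.24 log units; within the scatter). For compound 4 the estimated value is 5 nM, within an expected range of 1.5 nM to 20 nM.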

Compound 4, half-maximal inhibitory concentration: 7.48 nM
Compound 4: the middle estimate sits 1.5-fold (0.17 log units) below what was measured; low and high end bracket the measured number.
By their numbers in this assay, from the lowest: compound 3; then compound 4; then compound 2; then compound 1.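

In this assay, a second methyl on the ring, para to a methyl group, gives a 2.6-fold higher number from compound 3 to compound 4 (0.41 log units; beyond the scatter) and so weakens inhibition modestly, a shift that lies beyond the usual scatter. This carbon therefore does not accept the added methyl without a change in the number, though the price is small beside the earlier effect of moving the single methyl. The 2,5-dimethylphenyl ring still outperforms 4-methylphenyl, with a 4.6-fold lower number from compound 2 to compound 4 (0.66 log units; beyond the scatter) showing that the doubly substituted ring remains on the stronger side, while nothing shown explains the effect of the added methyl.

Still open, as far as these compounds go, is whether another group at this carbon, such as methoxy, a chlorine atom or an amine, would shift the number in the same direction. It is also unknown whether the same methyl would have a similar effect on a plain phenyl ring.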